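Chloro for methoxy on a chalcone-bearing imidazolone scaffold

A few compounds are considered here, and "the series" means these few. Any claim that something is new, unique, unknown or untested is made for them only; others in the source may bear on it.

Measured so far:
compound 1, `O=C(/C=C/c1cccc(O)c1)c1cccc(-n2cc(-c3ccc(Cl)cc3)[nH]c2=O)c1`, 1900 nM
compound 2, `COc1ccc(-c2cn(-c3cccc(C(=O)/C=C/c4ccc(O)c(OC)c4)c3)c(=O)[nH]2)cc1`, 3840 nM

In a functional assay on HT-29 cells (Homo sapiens) for inhibition (a higher number here means a weaker inhibitor of growth, a lower number a stronger inhibitor of growth), compound 2 gives the higher of the two numbers measured, and the number of compound 1 lies beyond the usual scatter below it. Compound 3, `COc1cc(/C=C/C(=O)c2cccc(-n3cc(-c4ccc(Cl)cc4)[nH]c3=O)c2)ccc1O`, has not been measured in this assay. It differs from compound 2 in one place: chloro in place of methoxy on an aromatic carbon. Within the data shown here, compound 1 also carries a chloro group on that ring, but it differs from compound 3 elsewhere as well, so the two values for compound 1 and compound 2 show only that the chloro-bearing compound gives the lower number. For compound 3, the step of a 1.7-fold lower number from compound 2 to compound 3 (0.22 log units; within the scatter) is expected to be a modest lowering of the number, possibly not beyond the scatter. The estimate for compound 3 in this assay is 2300 nM, with a range from 900 nM to 5500 nM.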

Compound 3, concentration for 50% growth inhibition: 2970 nM
For compound 3 the middle estimate is 1.3-fold (0.11 log units) below the measured one; measured number inside the range.
By their numbers in this assay, from the lowest: compounds 1, 3 and 2 (each within the scatter of the next, the first and the last beyond it).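

In this assay, chloro in place of methoxy on otherwise identical compounds gives a 1.3-fold lower number from compound 2 to compound 3 (0.11 log units; within the scatter), so 4-methoxyphenyl and 4-chlorophenyl cannot be told apart at this position, a point that the gap between compound 1 and compound 2, which differ in more than one place, could not settle. With the 4-chlorophenyl group held fixed, 4-hydroxy-3-methoxyphenyl in place of 3-hydroxyphenyl gives a 1.6-fold higher number from compound 1 to compound 3 (0.19 log units; within the scatter), so this second change also cannot be told apart from the scatter. No other measurement bears on these results.

As far as these compounds go, whether an amine or a carboxylic acid at the position of the chloro would move the number beyond the scatter remains open. A single pair also cannot show whether chloro and methoxy would read alike with a different group at the chalcone end.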